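From carbamoyl to (4-hydroxypiperidin-1-yl)carbonyl

The compounds below may be only part of what the source reports. "The series", "measured", "known", "first", "only" and "open" are said of these compounds alone.

Values in a physicochemical assay for solubility, read by HPLC, using the shake flask method, with a stated time of 2 h, at pH 2; on this read-out lower numbers stand for lower solubility and higher numbers for higher solubility:
- compound 1 `NC(=O)c1ccc(-c2cnc(N)c(-c3ccc(C(F)(F)F)cc3)n2)cc1`: 80000 nM
- compound 2 `Nc1ncc(-c2ccc(C(=O)N3CC[C@@H](O)C3)cc2)nc1-c1ccc(C(F)(F)F)cc1`: 103000 nM
- compound 3 `Nc1ncc(-c2ccc(C(=O)O)cc2)nc1-c1ccc(C(F)(F)F)cc1`: < 5000 nM (a limit, not a number)

Compound 1 and compound 2 give numbers within the scatter of each other, while compound 3 has only a limit. The unmeasured compound 4 `Nc1ncc(-c2ccc(C(=O)N3CCC(O)CC3)cc2)nc1-c1ccc(C(F)(F)F)cc1` differs from compound 1 by one swap: 4-hydroxypiperidin-1-yl in place of amino on a carbonyl carbon. In words, 4-hydroxypiperidin-1-yl takes the place of amino on a carbonyl carbon.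

Within the data shown here, no measured compound carries this exact group. The nearest measured change puts 3-hydroxypyrrolidin-1-yl on that same carbonyl carbon, and it gave a 1.3-fold higher number from compound 1 to compound 2 (0.11 log units; within the scatter). The two large steps, an at least 16-fold lower number from compound 1 to compound 3 (1.20 log units; beyond the scatter) and an at least 20-fold lower number from compound 2 to compound 3 (1.31 log units; beyond the scatter), put hydroxy on the carbonyl carbon instead of a ring, so they bear less on this swap. No step beyond the scatter is therefore expected in this assay.

The expected change is a 1.1-fold higher number from compound 1 to compound 4 (0.05 log units; within the scatter). For compound 4 the estimated value is 90000 nM, with an expected range from 35000 nM to 200000 nM.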

Compound 4, solubility: 119000 nM
Estimate against measurement, compound 4: 1.3-fold (0.12 log units) below; the measured number falls inside the stated range.
By their numbers in this assay, from the lowest: compounds 1, 2 and 4 (each within the scatter of the next). At a limit, below all of these: compound 3.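

In this assay, the carbonyl carbon now carries a six-membered non-aromatic ring and the reading stays level with that of the small amino group, with a 1.5-fold higher number from compound 1 to compound 4 (0.17 log units; within the scatter), and exchanging 3-hydroxypyrrolidin-1-yl for 4-hydroxypiperidin-1-yl also stays within the scatter, with a 1.2-fold higher number from compound 2 to compound 4 (0.06 log units; within the scatter). So two different hydroxylated rings and the plain amide now give numbers that cannot be told apart, while the one large step remains the one involving hydroxy on the carbonyl carbon, with an at least 23-fold higher number from compound 3 to compound 4 (1.37 log units; beyond the scatter). Compound 3 holds a limit, not a number: the limit of < 5000 nM in this assay, at which 1 of the 4 values shown sits.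

The compounds shown leave open how a piperidin-1-yl ring with no hydroxy group, or a ring carrying an amine in place of that hydroxy, would read in this assay. They also leave open how these compounds would read at any other pH.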